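Acetyl for Methylsulfonyl on the Urea Aryl Group

This account rests on a few compounds, and the source may have more. Where it says the series, first, only, none or still open, it means among the compounds named here.

Of the compounds shown here, three sharing one core have been tested in a functional assay on MDA-MB-231 cells (Homo sapiens) for antiproliferative activity, read by MTT assay, with a stated time of 72 h; on this read-out higher numbers stand for weaker inhibition and lower numbers for stronger inhibition. Compound 1 `O=C(Nc1cccc(-c2nc(-c3ccc(NC(=O)c4cccnc4)cc3Cl)no2)c1)Nc1ccc(Cl)c(C(F)(F)F)c1` gives 1900 nM. Compound 2 `C#Cc1ccc(NC(=O)Nc2cccc(-c3nc(-c4ccc(NC(=O)c5cccnc5)cc4Cl)no3)c2)cc1` reaches only the assay limit, > 10000 nM. Compound 3 `CS(=O)(=O)Nc1ccc(NC(=O)Nc2cccc(-c3nc(-c4ccc(NC(=O)c5cccnc5)cc4Cl)no3)c2)cc1Cl` gives 600 nM, the lowest of the two numbers; the step of a 3.2-fold lower number from compound 1 to compound 3 (0.50 log units; beyond the scatter) separates it from its nearest neighbour. Compound 4 `CC(=O)Nc1ccc(NC(=O)Nc2cccc(-c3nc(-c4ccc(NC(=O)c5cccnc5)cc4Cl)no3)c2)cc1Cl` differs from compound 3 in one place: acetyl in place of methylsulfonyl on a nitrogen on an aromatic ring. For the measured compounds named here, none of the measured steps exchanges this group; all three alter the aryl on the amide-type nitrogen, giving an at least 5.2-fold higher number from compound 1 to compound 2 (0.72 log units; beyond the scatter) and an at least 16-fold lower number from compound 2 to compound 3 (1.22 log units; beyond the scatter). These steps offer no direct guide for the present swap, so a number near that of compound 3 is expected for compound 4, a 1.5-fold higher number from compound 3 to compound 4 (0.18 log units; within the scatter). The estimate for compound 4 is 900 nM, within 300 nM to 3000 nM.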

Compound 4, half-maximal inhibitory concentration: > 10000 nM
Compound 4: only a limit was reported; the forecaster's own chance of this, stated with the estimate: 8%; middle value at least 11-fold (1.04 log units) away from the limit.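

In this assay, exchanging methylsulfonyl for acetyl on the nitrogen on an aromatic ring gives an at least 16-fold higher number from compound 3 to compound 4 (1.22 log units; beyond the scatter), so this position tolerates not every small acyl-type group. With the acetyl in place, the aryl group also compares poorly with the 4-chloro-3-(trifluoromethyl)phenyl of compound 1, giving an at least 5.2-fold higher number from compound 1 to compound 4 (0.72 log units; beyond the scatter), whereas the methanesulfonamido analogue compound 3 had the lower number. Compound 4 is reported only as a limit, and its step from compound 2 cannot be read, since both compounds sit at that limit: the limit of > 10000 nM in this assay, at which 2 of the 4 values shown sit.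

On these data alone, how far compound 4 lies past the limit stays open. So does how a free amine or a longer alkylsulfonyl chain on this nitrogen would behave.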